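The compounds below may be only part of what the source reports. "The series", "measured", "known", "first", "only" and "open" are said of these compounds alone.

Compound 3 `CC(C)c1nn(-c2ccc(C(N)=O)c(N[C@H]3CC[C@H](O)CC3)c2)c2nccc(-c3cccnc3)c12` carries the higher of the two plain numbers in a functional assay on SK-BR-3 cells (Homo sapiens) for inhibition, read by CellTiter-Glo, with a stated time of 72 h (on this read-out lower numbers stand for stronger inhibition and higher numbers for weaker inhibition), giving 464 nM. Its nearest neighbour is compound 1 `CC(C)c1nn(-c2ccc(C(N)=O)c(N[C@H]3CC[C@H](O)CC3)c2)c2nccc(-n3cnc(-c4cncnc4)c3)c12`, which gives 387 nM, and a 1.2-fold higher number from compound 1 to compound 3 (0.08 log units; within the scatter). Compound 2 `CC(C)c1nn(-c2ccc(C(N)=O)c(N[C@H]3CC[C@H](O)CC3)c2)c2nccc(-c3ccc4ccccc4c3)c12` is reported only as a limit of this assay, > 10000 nM; (the limit of > 10000 nM in this assay, at which 1 of the 3 values shown sits). The two steps that reach the limit are large: an at least 25-fold higher number from compound 1 to compound 2 (1.41 log units; beyond the scatter) and an at least 21-fold lower number from compound 2 to compound 3 (1.33 log units; beyond the scatter).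

Compound 4 `CC(C)c1nn(-c2ccc(C(N)=O)c(N[C@H]3CC[C@H](O)CC3)c2)c2nccc(-n3cnc(-c4ccccc4)c3)c12` differs from compound 3 in one place: 4-phenyl-1H-imidazol-1-yl in place of pyridin-3-yl on an aromatic carbon. The step from compound 1 to compound 3 shows that an imidazolyl bearing a six-membered heteroaryl and pyridin-3-yl give numbers within the scatter of each other, while the step from compound 1 to compound 2 shows that a carbon-only bicyclic aromatic group gives a far higher number. The new group keeps the imidazolyl but carries phenyl, so a step no larger than the scatter, or a small rise, is expected: a 1.2-fold higher number from compound 3 to compound 4 (0.07 log units; within the scatter). Compound 4 is therefore estimated at 550 nM, in the range 180 nM to 1800 nM.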

Compound 4, half-maximal inhibitory concentration: 276 nM
Beside the measured number, compound 4's estimate is 2.0-fold (0.30 log units) above it; the range from low to high includes it.
By their numbers in this assay, from the lowest: compounds 4, 1 and 3 (each within the scatter of the next). At a limit, above all of these: compound 2.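

Swapping the outer ring of the imidazolyl group gives a 1.4-fold lower number from compound 1 to compound 4 (0.15 log units; within the scatter) in this assay, so a nitrogen in that ring is not required for a number in this range among these compounds. Exchanging pyridin-3-yl for 4-phenyl-1H-imidazol-1-yl, on the aromatic carbon opposite the ring nitrogen, gives a 1.7-fold lower number from compound 3 to compound 4 (0.23 log units; within the scatter), so this position accepts either group without a change beyond the scatter. The exchange of naphthalen-2-yl for 4-phenyl-1H-imidazol-1-yl gives an at least 36-fold lower number from compound 2 to compound 4 (1.55 log units; beyond the scatter), which shows that a carbon-only aromatic ring at the end of the group does not by itself go with a reading as high as that of compound 2, whose value is a limit and not a number: the limit of > 10000 nM in this assay, at which 1 of the 4 values shown sits.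

As far as these compounds go, how a methoxy group or an amine on the phenyl ring would read stays open. So does the reading of a saturated ring such as morpholine at this position.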